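This account rests on a few compounds, and the source may have more. Where it says the series, first, only, none or still open, it means among the compounds named here.

Compound 1 `N#C/C(=C\N1CCN(C(=O)c2ccco2)C1=S)C(=O)Nc1ccc(Cl)cc1` and compound 2 `N#C/C(=C\N1CCN(C(=O)c2ccco2)C1=S)C(N)=O` share one core. In a functional assay on NCI-H522 cells (Homo sapiens) for inhibition, read by sulforhodamine B assay, with a stated time of 48 h (on this read-out higher numbers stand for weaker inhibition of growth and lower numbers for stronger inhibition of growth), compound 1 gives 16700 nM, and compound 2 gives 18700 nM, which places compound 2 at the top of the two numbers shown, though the gap, a 1.1-fold higher number from compound 1 to compound 2 (0.05 log units; within the scatter), is within the scatter. Compound 3 `N#C/C(=C\N1CCN(C(=O)c2ccco2)C1=S)C(=O)c1ccccc1` differs from compound 2 by phenyl in place of amino on a carbonyl carbon. Within the data shown here, the only measured step changes the group on the amide-type nitrogen, not the carbonyl carbon itself, and it stays within the scatter, so nothing points to a direction. Expected is a 1.0-fold lower number from compound 2 to compound 3 (0.02 log units; within the scatter), no larger than the scatter. Compound 3 is therefore estimated at 18000 nM, between 6000 nM and 55000 nM.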

Compound 3, concentration for 50% growth inhibition: 3700 nM
For compound 3 the middle estimate is 4.9-fold (0.69 log units) above the measured one; measured number below the stated range.
By their numbers in this assay, from the lowest: compound 3; then compounds 1 and 2 (each within the scatter of the next).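

In this assay, the group on the carbonyl carbon changes the number where the group on the amide-type nitrogen did not: benzoyl in place of carbamoyl gives a 5.1-fold lower number from compound 2 to compound 3 (0.70 log units; beyond the scatter) and phenyl in place of (4-chlorophenyl)amino gives a 4.5-fold lower number from compound 1 to compound 3 (0.65 log units; beyond the scatter) as well. Compound 1 also carries an aromatic ring, so among these compounds a ring alone does not set compound 3 apart. No measured evidence explains this shift. The compounds shown leave open whether the phenyl ring or the loss of the nitrogen on the carbonyl carbon carries the change; a methyl group there would bear on this.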